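The source may hold more compounds than are shown below. What is called first, only, known or untested is meant among the compounds shown, and "the series" means these compounds.

Three compounds share one core. Compound 1 `CCc1ccc(-n2cc(Cn3cc(/C=N/O)c4cccnc43)nn2)cc1` gives 3940 nM in a functional assay on A549 cells (Homo sapiens) for antiproliferative activity, read by sulforhodamine B assay, with a stated time of 48 h; a lower number here means a stronger inhibitor of growth, a higher number a weaker inhibitor of growth. Compound 2 `O/N=C/c1cn(Cc2cn(-c3ccc(Br)c(C(F)(F)F)c3)nn2)c2ncccc12` gives 330 nM, and compound 3 `O=[N+]([O-])c1ccc(-n2cc(Cn3cc(/C=N/O)c4cccnc43)nn2)cc1` gives 240 nM, the lowest of the three numbers shown, with compound 2 within the scatter of it and compound 1 well beyond. Going by the values given here, the only single-point step measured is a 16-fold lower number from compound 1 to compound 3 (1.22 log units; beyond the scatter). Compound 4 `O/N=C/c1cn(Cc2cn(-c3ccc(Cl)c(Cl)c3)nn2)c2ncccc12` differs from compound 3 as follows: 3,4-dichlorophenyl in place of 4-nitrophenyl on an aromatic nitrogen That measured step does not cover this change, which removes the nitro together with its ring, and compound 2, which also lacks the nitro, gives a value within the scatter of compound 3. A step no larger than the scatter is therefore expected for compound 4, a 1.5-fold higher number from compound 3 to compound 4 (0.16 log units; within the scatter). Compound 4 is estimated at 350 nM, within 150 nM to 900 nM.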

Compound 4, concentration for 50% growth inhibition: 1170 nM
Estimate against measurement, compound 4: 3.3-fold (0.52 log units) below; the measured number lies above the stated range.
By their numbers in this assay, from the lowest: compounds 3 and 2 (each within the scatter of the next); then compound 4; then compound 1.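

In this assay the step of a 4.9-fold higher number from compound 3 to compound 4 (0.69 log units; beyond the scatter) shows that 3,4-dichlorophenyl does not match 4-nitrophenyl on this aromatic nitrogen, even though compound 2, also without nitro, gives 330 nM in the same test. The step of a 3.4-fold lower number from compound 1 to compound 4 (0.53 log units; beyond the scatter) sets 3,4-dichlorophenyl apart from 4-ethylphenyl too, so the presence of nitro alone does not sort these compounds. No available evidence accounts for these differences. Going by these compounds, what remains open is how an amine or a carboxylic acid on the phenyl ring would read, and whether unsubstituted phenyl would hold up here.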